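The source may report more compounds than this note shows. Statements on the series, on what has been measured and on what is new or still open speak of the compounds shown alone.

All values below come from a functional assay on HEp-2 cells (Homo sapiens) for cytotoxicity, read by MTT assay; on this read-out higher numbers stand for weaker inhibition and lower numbers for stronger inhibition.

Compound 1, `CC1=NNC(=O)C1C(c1c(-c2ccccc2)[nH]c2ccc(C)cc12)c1c(-c2ccccc2)[nH]c2ccc(Cl)cc12`: 32400 nM
Compound 2, `COc1ccc2[nH]c(-c3ccccc3)c(C(c3c(-c4ccccc4)[nH]c4ccc(C)cc34)C3C(=O)NN=C3C)c2c1`: 3500 nM
Compound 3, `CC1=NNC(=O)C1C(c1c[nH]c2ccccc12)c1c(-c2ccccc2)[nH]c2ccc(Cl)cc12`: a limit only, > 100000 nM

Compound 1 and compound 2 share one core and differ in a single place; the change is methoxy in place of chloro on an aromatic carbon. In this assay this change gave a 9.3-fold lower number from compound 1 to compound 2 (0.97 log units; beyond the scatter). Compound 3 rests on a different core. How the core of compound 3 differs from the core of compound 1 is not broken down here. For compound 3, this assay reports only a limit, not a number. Among the three measured values, one sits at the limit of > 100000 nM in this assay, at which 1 of the 3 values shown sits.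

Compound 4, `COc1ccc2[nH]c(-c3ccccc3)c(C(c3c[nH]c4ccccc34)C3C(=O)NN=C3C)c2c1`, has not yet been measured in this assay. It comes from compound 3 by the same change: methoxy in place of chloro on an aromatic carbon. The place of the change is described in the same words for both pairs, so the two steps are of the same kind and at the same place.

If the change acts on the core of compound 3 as it acted on the core of compound 1, a lower number is expected for compound 4. Because compound 3 gives only a limit of > 100000 nM in this assay, the size of the expected step cannot be fixed closely, and a good chance remains that compound 4 too returns only a limit. The expected step is an at least 3.3-fold lower number from compound 3 to compound 4 (0.52 log units; beyond the scatter). Compound 4 is estimated at about 30000 nM, within a range from 8000 nM to 120000 nM.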

Compound 4, half-maximal inhibitory concentration: 5300 nM
For compound 4 the middle estimate is 5.7-fold (0.75 log units) above the measured one; the whole stated range lies above it.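

In this assay, methoxy in place of chloro on an aromatic carbon again moved the result toward stronger inhibition, here with an at least 18-fold lower number from compound 3 to compound 4 (1.27 log units; beyond the scatter). Compound 3 gives only a limit, > 100000 nM, and not a number, so this step has a floor but no fixed size. The change therefore lowered the number on both cores shown, but two cores make no general rule, and these results do not show whether the change is worth the same amount on each: the same change on two cores in this assay, a 9.3-fold lower number (0.97 log units; beyond the scatter) from compound 1 to compound 2 and an at least 18-fold lower number (1.27 log units; beyond the scatter) from compound 3 to compound 4; the limit leaves it open whether they differ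

The compounds shown carry only chloro or methoxy at this place, which leaves open how a fluoro group, a hydroxy group, an amine, a carboxylic acid or a longer ether chain would behave there on either core. They also leave open whether the same change would lower the number on a third core, and a measured number in place of the limit for compound 3 would be needed before the two steps could be compared in size.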